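The compounds below may be only part of what the source reports. "The series", "measured", "known", "first", "only" and "open" are said of these compounds alone.

Of the compounds shown here, three have been measured in an ADME assay on HepG2 cells (Homo sapiens) for cytotoxicity, read by MTT assay, with a stated time of 48 h; on this read-out lower numbers stand for higher toxicity in this test and higher numbers for lower toxicity in this test. Compound 1, with the structure `CC(=O)OC[C@H]1O[C@H](OC[C@H](Cn2cc(COc3ccc(-c4noc(NC5CCCCC5)n4)cc3)nn2)OC(C)=O)C=C[C@@H]1OC(C)=O`, gives 99.5 ug/mL. Compound 2, with the structure `CC(=O)OC[C@H]1O[C@H](OC[C@@H](Cn2cc(CN(c3nc(-c4cccc(C)c4)no3)C3CCCCC3)nn2)OC(C)=O)C=C[C@@H]1OC(C)=O`, gives 39.2 ug/mL. Compound 3, with the structure `C#CCN(c1nc(-c2ccc(OC)cc2)no1)C1CCCCC1`, gives 72.5 ug/mL. Compound 2 sits at the low end of these three numbers: compound 3 lies within the usual scatter of it, while compound 1 lies beyond that scatter.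

Compound 4, with the structure `COc1ccc(-c2noc(N(Cc3cn(C[C@H](CO[C@@H]4C=C[C@H](OC(C)=O)[C@@H](COC(C)=O)O4)OC(C)=O)nn3)C3CCCCC3)n2)cc1`, has not yet been measured in this assay. It differs from compound 2 in one place: 4-methoxyphenyl in place of 3-methylphenyl on an aromatic carbon. Within the data shown here, the same 4-methoxyphenyl group already sits on the core of compound 3, whose number in this assay is close to that of compound 2, and no other single-change pair is available to show what this exchange does.

The step of a 1.3-fold higher number from compound 2 to compound 4 (0.11 log units; within the scatter) is therefore expected to be small, toward a somewhat higher number, and to stay within the scatter. Compound 4 is estimated at 50 ug/mL in this assay, with a likely range from 25 ug/mL to 100 ug/mL.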

Compound 4, half-maximal cytotoxic concentration: 141 ug/mL
Estimate against measurement, compound 4: 2.8-fold (0.45 log units) below; measured number outside the range, above it.
By their numbers in this assay, from the lowest: compounds 2, 3, 1 and 4 (each within the scatter of the next, the first and the last beyond it).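

In this assay, among these compounds, the exchange of 3-methylphenyl for 4-methoxyphenyl gives a 3.6-fold higher number from compound 2 to compound 4 (0.56 log units; beyond the scatter), the only single-change step available here. It shows that the group on this aromatic carbon, two ring bonds from the ring atom that bears a large group, can move the read-out beyond the scatter, here toward lower toxicity in this test, while the rest of the molecule stays the same. None of the data shown offers an explanation for the size of this step.

The exchange alters both the substituent on the phenyl ring and its place on that ring, and these two compounds do not separate the two. As far as these compounds go, what 4-methylphenyl or 3-methoxyphenyl would give at this position on the same core remains open, so neither the methoxy group nor its placement can be credited with the step.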